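The compounds below may be only part of what the source reports. "The series", "measured", "known", "first", "only" and "open" are said of these compounds alone.

Measured in a functional assay on Hep 3B2 cells (Homo sapiens) for cytotoxicity, read by MTT assay; a lower number here means a stronger inhibitor, a higher number a weaker inhibitor:
- Compound 1 `COc1ccc(OC)c(C(=O)/C=C/c2ccoc2)c1`: 12000 nM
- Compound 2 `COc1ccc(OC)c(C(=O)/C=C/c2ccsc2)c1`: 5700 nM

Compound 2 holds the lower of the two numbers, which makes it the stronger inhibitor of this pair. Compound 3 `COc1ccc(OC)c(C(=O)/C=C/c2ccc(C)s2)c1` differs from it on a double-bonded chain carbon bound to a double-bonded chain carbon: 5-methylthiophen-2-yl in place of thiophen-3-yl on a double-bonded chain carbon bound to a double-bonded chain carbon. Among the measured compounds shown here, only one measured step bears on this, the modest 2.1-fold lower number from compound 1 to compound 2 (0.32 log units; beyond the scatter), and it involves a different ring exchange with no methyl group, so it is a loose guide. In this assay, a small shift towards a lower number is therefore expected, perhaps none beyond the scatter. The expected step is a 1.4-fold lower number from compound 2 to compound 3 (0.15 log units; within the scatter). Compound 3 is estimated at 4000 nM, with an expected range of 1500 nM to 13000 nM.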

Compound 3, half-maximal inhibitory concentration: 3400 nM
For compound 3 the middle estimate is 1.2-fold (0.07 log units) above the measured one; low and high end bracket the measured number.
By their numbers in this assay, from the lowest: compounds 3 and 2 (each within the scatter of the next); then compound 1.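

Swapping in 5-methylthiophen-2-yl for thiophen-3-yl gives a 1.7-fold lower number from compound 2 to compound 3 (0.22 log units; within the scatter), so this position on the chain accepts the methyl-bearing ring with no change beyond the scatter. The same group in place of furan-3-yl gives a 3.5-fold lower number from compound 1 to compound 3 (0.55 log units; beyond the scatter), a wider gap that lies beyond the scatter. No evidence on hand explains either result. The swap alters both the ring's point of attachment and the methyl group, and these two changes cannot be told apart here. Plain thiophen-2-yl would separate them, while an ethyl group or an amine on the ring remains an open question.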